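Nitro for methoxycarbonyl on the pendant aryl ring

The source may hold more compounds than are shown below. What is called first, only, known or untested is meant among the compounds shown, and "the series" means these compounds.

Compound 1 `CN(CC1=CC[C@H]2C[C@@H]1C2(C)C)Cc1ccccc1` in an assay on HEK293 cells for displacement of a labelled ligand from C-X-C chemokine receptor type 3 (Homo sapiens) (on this read-out lower numbers stand for stronger inhibition and higher numbers for weaker inhibition), gives 15800 nM. Within the data shown here, compound 2 `CN(CC1=CC[C@H]2C[C@@H]1C2(C)C)Cc1ccc(F)cc1` in this assay gives 6310 nM; the step of a 2.5-fold lower number from compound 1 to compound 2 (0.40 log units; beyond the scatter) is the only change between two numbered values. Compound 3 `COC(=O)c1cccc(-c2ccc(CN(C)CC3=CC[C@H]4C[C@@H]3C4(C)C)cc2)c1` extends the benzyl group by a second aromatic ring bearing a methoxycarbonyl. In this assay compound 3 is reported only as a limit, > 316 nM, and not as a number. Where compound 3 stands among the values is set by the limit of > 316 nM in this assay, at which 1 of the 3 values shown sits; it is the one entry without a numbered result.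

Compound 4 `CN(CC1=CC[C@H]2C[C@@H]1C2(C)C)Cc1ccc(-c2cccc([N+](=O)[O-])c2)cc1` differs from compound 3 by nitro in place of methoxycarbonyl on an aromatic carbon. Among the measured compounds shown here, no measured step concerns an exchange of this kind: the single step on record, a 2.5-fold lower number from compound 1 to compound 2 (0.40 log units; beyond the scatter), is a small change at a different position of a different ring and lends no direction to the present one. The expectation for this assay is therefore a step of no clear size or direction beyond the scatter, with a fair chance that compound 4 again returns only a limit. The expected step is a step that the limit leaves unreadable from compound 3 to compound 4. Compound 4 is estimated at 2000 nM, in a range from 316 nM to 15000 nM.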

Compound 4, inhibition constant: 2000 nM
Compound 4: the middle estimate sits on the measured number at the digits printed, and the stated range covers the measured number.
By their numbers in this assay, from the lowest: compound 4; then compound 2; then compound 1.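

Replacing fluoro on this aromatic carbon by 3-nitrophenyl gives a 3.2-fold lower number from compound 2 to compound 4 (0.50 log units; beyond the scatter) in this assay, and 3-nitrophenyl in place of hydrogen gives a 7.9-fold lower number from compound 1 to compound 4 (0.90 log units; beyond the scatter). Among these compounds, the earlier numbered compounds carried only hydrogen or fluoro here, so these steps are the first numbered evidence that a second aromatic ring can sit at this carbon with the number falling rather than rising, and the two steps are both beyond the scatter. The exchange of methoxycarbonyl for nitro on the pendant ring cannot be read as a step, because compound 3 is reported only as a limit and not as a number: the limit of > 316 nM in this assay, at which 1 of the 4 values shown sits.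

Going by these compounds, whether the lower number of compound 4 belongs to the second aromatic ring itself or to the nitro it carries stays open, as does any ranking of nitro against methoxycarbonyl at this place. An unsubstituted phenyl at the same carbon would separate the ring from its substituent, and an amine or a carboxylic acid in place of the nitro would show how much the pendant ring's substituent matters in this series.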